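The source may hold more compounds than are shown below. What is called first, only, known or untested is meant among the compounds shown, and "the series" means these compounds.

Two compounds of this series have numbers in a functional assay on CHO-K1 cells for agonist activity at Glucose-dependent insulinotropic receptor (Homo sapiens), read by cAMP accumulation and immunoassay, with a stated time of 1 h; a higher number here means that more compound is needed for the effect, a lower number that less compound is needed. Compound 1, `CCOC(=O)N1CCC(Oc2cc(Oc3ccc(/C=C4\SC(=O)NC4=O)cc3)ncn2)CC1`, gives 790 nM in this assay. Compound 2, `CCOC(=O)N1CCC(Oc2cc(Oc3cccc(/C=C4\SC(=O)NC4=O)c3)ncn2)CC1`, gives 819 nM in this assay. Compound 2 stands at the higher of the two numbers, but its nearest neighbour is compound 1 and the gap between them lies within the scatter, so the two read as equal. Within the data shown here, no step between measured compounds that differ in one place is available, so nothing measured so far shows what a change at the ethoxycarbonyl does.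

Compound 3, `O=C1NC(=O)/C(=C/c2cccc(Oc3cc(OC4CCN(C(=O)OCc5ccccc5)CC4)ncn3)c2)S1`, is not yet measured in this assay. It differs from compound 2 in one place: phenyl in place of methyl on a saturated chain carbon bound to an oxygen next to a carbonyl group. The same difference, cut one bond further out, reads ethoxycarbonyl to benzyloxycarbonyl. Among the measured compounds shown here, with no measured step of this kind to lean on, the expectation is a change that may fall within the scatter or be a small step downward in the number; a large move in either direction is not expected. For compound 3 the estimate in this assay is 600 nM, with a range from 200 nM to 2000 nM. As a step, this estimate means a 1.4-fold lower number from compound 2 to compound 3 (0.14 log units; within the scatter).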

Compound 3, half-maximal effective concentration: 153 nM
Compound 3: the middle estimate sits 3.9-fold (0.59 log units) above what was measured; the whole stated range lies above it.
By their numbers in this assay, from the lowest: compound 3; then compounds 1 and 2 (each within the scatter of the next).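

In this assay the position on a saturated chain carbon bound to an oxygen next to a carbonyl group now has its first readable step: phenyl in place of methyl gives a 5.4-fold lower number from compound 2 to compound 3 (0.73 log units; beyond the scatter) and so this end of the molecule does bear on the number. Compounds 1 and 2 could not show this, as they carry the same ethoxycarbonyl and differ only elsewhere. The data shown offer no measurement that explains why the number falls with benzyloxycarbonyl.

Among these compounds, the single step leaves open whether the aromatic ring itself matters or whether any larger group here would do, which a cyclohexyl ring in place of the phenyl, a longer chain such as propyl in place of the ethyl, or a pyridine ring in place of the phenyl would separate. It also leaves open whether benzyloxycarbonyl gives a similar step on the core of compound 1, and whether substituents on the phenyl, such as a fluorine or a methoxy group, move the number further.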